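The source may report more compounds than this note shows. Statements on the series, on what has been measured and on what is new or still open speak of the compounds shown alone.

For the measured compounds named here, in a functional assay on CCRF-CEM cells (Homo sapiens) for antiproliferative activity, read by MTT assay (on this read-out higher numbers stand for weaker inhibition and lower numbers for stronger inhibition), two compounds have numbers so far. Compound 1 `C/C(=N\Nc1nc2ccccc2o1)c1ncccn1` gives 130 nM, and compound 2 `C/C(=N\Nc1nc2ccccc2o1)c1cnccn1` gives 430 nM on the same read-out. Compound 2 therefore stands at the higher of the two numbers, which means the weaker inhibition of the pair.

Compound 3 `C/C(=N\Nc1nc2ccccc2o1)c1cccnn1` is the next to be read. It carries pyridazin-3-yl in place of pyrazin-2-yl on a carbon with a double bond to nitrogen.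

Going by the values given here, only one measured step bears on this change. It is also an exchange of one ring for another on the same carbon, pyrazin-2-yl in place of pyrimidin-2-yl, and it came out modest but beyond the scatter (a 3.3-fold higher number from compound 1 to compound 2 (0.52 log units; beyond the scatter)). One step cannot fix a direction for a different ring, so a step beyond the scatter is not expected, and the range stays wide on both sides. The expected step is a 1.4-fold lower number from compound 2 to compound 3 (0.16 log units; within the scatter) in this assay, a slight lean towards the lower number. For compound 3 the estimated value is 300 nM, with an expected range from 100 nM to 900 nM in the same read-out.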

Compound 3, half-maximal inhibitory concentration: 720 nM
Compound 3: the middle estimate sits 2.4-fold (0.38 log units) below what was measured; measured number inside the range.
By their numbers in this assay, from the lowest: compound 1; then compounds 2 and 3 (each within the scatter of the next).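

In this assay, the exchange of pyrazin-2-yl for pyridazin-3-yl on a carbon with a double bond to nitrogen gives a 1.7-fold higher number from compound 2 to compound 3 (0.22 log units; within the scatter) and so does not separate these two rings, which also have identical printed counts of heavy atoms, hetero atoms and hydrogen-bond acceptors. The exchange of pyrimidin-2-yl for pyridazin-3-yl gives a 5.5-fold higher number from compound 1 to compound 3 (0.74 log units; beyond the scatter) and, taken with the earlier step from pyrimidin-2-yl to pyrazin-2-yl, sets compound 1 apart as the strongest inhibitor of the three, with both of its steps beyond the scatter. The data at hand offer no measurement that accounts for this difference among the rings.

Still open, as far as these compounds go, is whether pyrimidin-2-yl is itself the source of the advantage, which a comparison with pyridin-2-yl or plain phenyl at this place could test. Also unresolved is whether an amine or a methoxy group on the pyrimidin-2-yl ring would keep, lose or extend the standing of compound 1 on this read-out.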